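Methylation of the aromatic hydroxy in a chromone series

This account rests on a few compounds, and the source may have more. Where it says the series, first, only, none or still open, it means among the compounds named here.

The series rests on a shared core carrying a trifluoromethyl-substituted phenyl ring. Compound 1 `CC(=O)Nc1ccc2oc(-c3cccc(C(F)(F)F)c3)c(O)c(=O)c2c1` bears an acetyl on its aromatic nitrogen, and in an ADME assay on MT4 cells (Homo sapiens) for cytotoxicity, read by MTT assay, with a stated time of 4 days (a lower number here means that less compound is tolerated, a higher number that more compound is tolerated), compound 1 gives 5700 nM. Compound 2 `Nc1ccc2oc(-c3cccc(C(F)(F)F)c3)c(O)c(=O)c2c1` carries a hydrogen in place of that acetyl, and in this assay compound 2 gives 8100 nM. Going by the values given here, the only measured step, a 1.4-fold higher number from compound 1 to compound 2 (0.15 log units; within the scatter), is within the scatter, so compound 2 shows the higher of the two numbers without standing apart from compound 1.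

Compound 3 `COc1c(-c2cccc(C(F)(F)F)c2)oc2ccc(N)cc2c1=O` differs from compound 2 as follows: methyl in place of hydrogen on an oxygen on an aromatic ring. Among the compounds with values here, no measured pair in the set involves this change on the aromatic oxygen; the one step available concerns the aromatic nitrogen and offers no guide. The data therefore give no basis for expecting a shift beyond the scatter in this assay in either direction.

For compound 3 in this assay the estimate is 8000 nM, with a range from 3000 nM to 20000 nM. The expected step is a 1.0-fold lower number from compound 2 to compound 3 (0.01 log units; within the scatter).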

Compound 3, half-maximal cytotoxic concentration: 73100 nM
Compound 3: the middle estimate sits 9.1-fold (0.96 log units) below what was measured; measured number above the stated range.
By their numbers in this assay, from the lowest: compounds 1 and 2 (each within the scatter of the next); then compound 3.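

Going by these compounds alone, putting methyl in place of hydrogen on the oxygen on the aromatic ring, hydroxy to methoxy, is the first change in this set to move the number in this assay beyond the scatter, with a 9.0-fold higher number from compound 2 to compound 3 (0.96 log units; beyond the scatter) in the direction of more compound being tolerated. The earlier change at the aromatic nitrogen, a 1.4-fold higher number from compound 1 to compound 2 (0.15 log units; within the scatter), stayed within the scatter, so the hydroxy position is the one place here where a single small change has shifted this read-out, although that rests on one pair alone. Nothing at hand speaks to why the number moves at this position.

Whether the shift holds with the acetyl on the nitrogen remains open, since the compounds shown carry methoxy only alongside the free amino group of compound 3. On these data alone, it is also open whether the shift is particular to methyl, or whether an ethyl, a longer chain or an acetyl on the same oxygen would move the number in this assay as far, less far or further.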